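The source may hold more compounds than are shown below. What is called first, only, known or untested is meant among the compounds shown, and "the series" means these compounds.

Three ureas have so far been measured in an ADME assay on the whole organism with Oryza sativa as the target, tested at 0.1 uM; a higher number here means a weaker effect of the compound at the concentration tested, a lower number a stronger effect. Compound 1 `CCc1cccc(NC(=O)N[C@H](C)c2ccccc2)c1` gives 97%; compound 2 `CCc1cccc(NC(=O)N[C@@H](C)c2ccccc2)c1` gives 100%; compound 3 `CC(C)c1ccccc1NC(=O)N[C@H](C)c1ccccc1` gives 103%. Compound 2 stands in the middle of the three numbers, with compound 1 and compound 3 both within the scatter of it. Among the measured compounds shown here, the only single-point step recorded is a number 3 percentage points higher from compound 1 to compound 2 (within the scatter), which rests on (the fact that compounds 1 and 2 differ only in the configuration as drawn). Compound 4 `C[C@H](NC(=O)Nc1cccc(Br)c1)c1ccccc1` differs from compound 2 by bromo in place of ethyl on an aromatic carbon. For the measured compounds named here, no measured step covers such a change; the one step available stayed within the scatter, and all three numbers cluster closely. In this assay compound 4 is therefore expected to show a number 1 percentage points lower from compound 2 to compound 4 (within the scatter), nothing beyond the scatter. The estimate for compound 4 is 99%, expected to fall between 88% and 110%.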

Compound 4, a percentage reported as activity, at one concentration (the size of the read-out at that concentration, not a potency): 100%
Compound 4: the middle estimate sits 1 percentage points below what was measured, within the range that was stated.
By their numbers in this assay, from the lowest: compounds 1, 2, 4 and 3 (each within the scatter of the next).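

In this assay, bromo in place of ethyl on an aromatic carbon, meta to a large group, gives no change at the digits printed from compound 2 to compound 4 (within the scatter). Among the compounds shown here, this is the first step to change a group on this ring rather than a configuration, and exchanging the two-carbon ethyl for the single bromine atom leaves the read-out within the scatter. Nothing on record bears on the reason for this result.

On these data alone, it remains open whether an amine, a carboxylic acid or a longer chain at this aromatic carbon would move the number beyond the scatter. The same question holds for changes elsewhere on the shared core.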